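This account rests on a few compounds, and the source may have more. Where it says the series, first, only, none or still open, it means among the compounds named here.

Within the data shown here, in a functional assay on MCF7 cells (Homo sapiens) for antiproliferative activity, read by MTT assay, with a stated time of 48 h (a higher number here means a weaker inhibitor, a lower number a stronger inhibitor), compound 1 `CC(C)=CCC[C@]1(C)/C=C/[C@@H](OC(=O)C=C(C)C)[C@](C)(O)/C=C/C(=O)/C(C=O)=C\C1` gives 12600 nM and compound 2 `CC(C)=CCC[C@]1(C)/C=C/[C@@H](OC(=O)C=C(C)C)[C@](C)(O)/C=C/C(=O)/C(CN(C)C)=C\C1` gives 690 nM as the lower of the two numbers so far. Compound 3 `CCN(CC)C/C1=C/C[C@](C)(CCC=C(C)C)/C=C/[C@@H](OC(=O)C=C(C)C)[C@](C)(O)/C=C/C1=O` has not yet been measured. It differs from compound 2 by diethylamino in place of dimethylamino on a saturated chain carbon bound to a double-bonded ring carbon with diethylamino in place of dimethylamino on a saturated chain carbon bound to a double-bonded ring carbon. Among the measured compounds shown here, only one measured step bears on this change, and only indirectly. That step is an 18-fold lower number from compound 1 to compound 2 (1.26 log units; beyond the scatter) and it lies beyond the scatter, but it replaced formyl with (dimethylamino)methyl and leaves the effect of exchanging the amine groups untested. A change of that large size is therefore not expected in this assay, and any shift should stay within the scatter, perhaps toward a slightly higher number. The expected step is a 1.3-fold higher number from compound 2 to compound 3 (0.12 log units; within the scatter) in this estimate. For compound 3 the estimated value is 900 nM with an expected range from 300 nM to 2700 nM in this assay.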

Compound 3, half-maximal inhibitory concentration: 130 nM
For compound 3 the middle estimate is 6.9-fold (0.84 log units) above the measured one; the whole stated range lies above it.
By their numbers in this assay, from the lowest: compound 3; then compound 2; then compound 1.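

In this assay the amine on this saturated chain carbon bound to a double-bonded ring carbon proves not to be interchangeable: diethylamino in place of dimethylamino gives a 5.3-fold lower number from compound 2 to compound 3 (0.72 log units; beyond the scatter) and so the result depends on which groups the nitrogen carries, not only on an amine being present. Replacing formyl with (diethylamino)methyl gives a 97-fold lower number from compound 1 to compound 3 (1.99 log units; beyond the scatter) and this exceeds the earlier 18-fold lower number from compound 1 to compound 2 (1.26 log units; beyond the scatter) as the gain available at this position. Nothing measured here gives a reason for the difference between the two amines.

Only two amines are shown, so they set no trend, and it remains open whether a longer chain on the nitrogen, as in dipropylamino, would continue the change. Cyclic amines such as pyrrolidine or morpholine, and a secondary amine such as ethylamino, also remain open.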